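One Carbon Longer: Ethylamino to Propylamino on a Shared Core

The compounds below may be only part of what the source reports. "The series", "measured", "known", "first", "only" and "open" are said of these compounds alone.

Of the compounds shown here, two built on the same core have so far been tested in a functional assay on the whole organism for inhibition, with Mus musculus as the target, read by paw edema, with a stated time of 180 min, at a dose of 200 mg/kg by the oral route; a lower number here means a weaker effect, a higher number a stronger effect of the compound at the dose given. Compound 1 `CCNc1nnc(Cn2c(=O)oc3ccc(C)cc32)s1` gives 71.3% in this assay, the higher of the two numbers recorded. Compound 2 `CCNC(=S)NNC(=O)Cn1c(=O)oc2ccc(C)cc21` differs from compound 1 in several places. In this assay compound 2 gives 54.6%, and the gap between the two numbers lies beyond the usual scatter. Compound 3 `CCCNc1nnc(Cn2c(=O)oc3ccc(C)cc32)s1` has not yet been measured. It differs from compound 1 in one spot only: methyl in place of hydrogen on a saturated chain carbon, two bonds along the chain from a nitrogen on an aromatic ring. Read one bond further out, this is ethylamino becoming propylamino. Going by the values given here, no measured pair shows what one added methyl does on this chain, so the expectation rests on compound 1 alone, and such a small change is expected to shift the number little, if at all, beyond the scatter. The step of a number 1.3 percentage points lower from compound 1 to compound 3 (within the scatter) is the estimated size of that shift. Compound 3 is expected to reach about 70% in this assay, between 58% and 82%.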

Compound 3, a percentage reported as inhibition, in the whole organism at one dose (the size of the read-out at that dose, not a potency): 39.4%
Compound 3: middle estimate off by 30.6 percentage points, on the high side; measured number below the stated range.
By their numbers in this assay, from the lowest: compound 3; then compound 2; then compound 1.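

Going by these compounds alone, this pair is the first to differ in one place only, and it shows that this position on the chain is far from indifferent. Going from ethylamino to propylamino in this assay gives a number 31.9 percentage points lower from compound 1 to compound 3 (beyond the scatter), so a single added methyl on the saturated chain carbon can change the effect at this dose by a large amount. Nothing available accounts for the fall, and the reason for it remains unknown.

One step cannot show whether the read-out keeps falling as the chain grows or whether the drop is specific to propylamino. A longer chain such as butylamino, a shorter one such as methylamino, or a branched group such as isopropylamino on the same core would each leave a different picture of how this position responds.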